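The source may hold more compounds than are shown below. What is called first, only, known or untested is meant among the compounds shown, and "the series" means these compounds.

Two compounds of this set have been examined in a functional assay (ileum) for inhibition, with Cavia porcellus as the target (on this read-out lower numbers stand for an effect already at smaller amounts and higher numbers for an effect only at larger amounts of compound), and both returned only a limit. Compound 1 `CC(C)C(C)NC1=NS(=O)(=O)c2cccnc2N1` carries a 1,2-dimethylpropyl group on its amine and an unsubstituted ring; in this assay compound 1 gives > 300 uM, which is a limit of the measurement and not a number. Compound 2 `CC(C)NC1=NS(=O)(=O)c2cc(Cl)cnc2N1` carries instead an isopropylamino group together with a chlorine on the ring; in this assay compound 2 gives > 300 uM, again a limit rather than a measured value. Compound 2 therefore stands at the ceiling of what has been recorded, a position described by the limit of > 300 uM in this assay, at which 2 of the 2 values shown sit. Compound 3 `CC(C)C(C)NC1=NS(=O)(=O)c2cc(Cl)cnc2N1` has not yet been measured; it differs from compound 2 by isopropyl in place of methyl on a saturated chain carbon bound to an amine nitrogen and a saturated chain carbon. With both neighbours at the limit, no step beyond the scatter in either direction is expected from compound 2 to compound 3, the expected step being a step that the limit leaves unreadable from compound 2 to compound 3. Compound 3 is accordingly estimated at 400 uM, within a range from 150 uM to 1500 uM, most probably reported once more as a limit.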

Compound 3, concentration for half-maximal effect: > 300 uM
Compound 3: a limit, no number; the forecaster's own chance of this, stated with the estimate: 85%; the middle value lies beyond the limit too.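

No step can be read from compound 2 to compound 3 or from compound 1 to compound 3, since in this assay all three compounds return only a limit: the limit of > 300 uM in this assay, at which 3 of the 3 values shown sit.

The compounds shown leave open whether isopropyl in place of methyl, or chloro in place of hydrogen, changes the result in this assay at all.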